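Chloro on the benzyloxy ring, thiourea and urea cores

This account rests on a few compounds, and the source may have more. Where it says the series, first, only, none or still open, it means among the compounds named here.

Measured so far:
compound 1 `Cc1ccc(NC(=S)NC(=O)c2ccc(OCc3ccccc3)cc2)cc1-c1nc2ccccc2[nH]1`: in a functional assay on SW-620 cells (Homo sapiens) for inhibition, read by MTT assay, with a stated time of 48 h (a higher number here means a weaker inhibitor, a lower number a stronger inhibitor), compound 1 gives 67100 nM.
compound 2 `Cc1ccc(NC(=S)NC(=O)c2ccc(OCc3cccc(Cl)c3)cc2)cc1-c1nc2ccccc2[nH]1`: in this assay compound 2 reaches only a limit of the assay, > 100000 nM.
compound 3 `Cc1ccc(NC(=O)NC(=O)c2ccc(OCc3ccccc3)cc2)cc1-c1nc2ccccc2[nH]1`: in this assay compound 3 gives 30100 nM.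

The change chloro in place of hydrogen on an aromatic carbon gave an at least 1.4-fold higher number from compound 1 to compound 2 (0.17 log units; that floor lies within the scatter); compound 2 sits at the limit of > 100000 nM in this assay, at which 1 of the 3 values shown sits. Compound 3 shows the lowest of the two numbers. The difference between the cores of compound 1 and compound 3 is not broken down here.

Compound 4 `Cc1ccc(NC(=O)NC(=O)c2ccc(OCc3cccc(Cl)c3)cc2)cc1-c1nc2ccccc2[nH]1` is not yet measured. It differs from compound 3 by chloro in place of hydrogen on an aromatic carbon, the same change as that from compound 1 to compound 2. For compound 4 a step of a 1.8-fold higher number from compound 3 to compound 4 (0.26 log units; within the scatter) is expected in this assay, because the same change gave an at least 1.4-fold higher number from compound 1 to compound 2 (0.17 log units; that floor lies within the scatter). Compound 4 is therefore estimated at 55000 nM, with a range from 25000 nM to 100000 nM.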

Compound 4, half-maximal inhibitory concentration: 16000 nM
The estimate for compound 4 lay 3.4-fold (0.54 log units) above the measured number; measured number outside the range, below it.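

In this assay, chloro in place of hydrogen on the core of compound 3 gives a 1.9-fold lower number from compound 3 to compound 4 (0.27 log units; within the scatter), so this step alone shows no clear effect of the change. Two pairs set no rule for other cores and give no cause for the gap, but the change did not carry across these two cores as a single step: the same change on two cores in this assay, an at least 1.4-fold higher number (0.17 log units; that floor lies within the scatter) from compound 1 to compound 2 and a 1.9-fold lower number (0.27 log units; within the scatter) from compound 3 to compound 4, at least 2.8-fold (0.44 log units) apart, beyond the scatter of two such steps
The value of compound 2, > 100000 nM, is a limit of the assay and not a number.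

Still open, on these data alone, is whether fluoro, methoxy or an amine in place of the chloro would also give different steps on the two cores. Also open, as far as these compounds go, is how either core responds when a longer chain replaces the benzyl.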